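Swapping an Imidazole for a Triazole on the Amide Tail

This account rests on a few compounds, and the source may have more. Where it says the series, first, only, none or still open, it means among the compounds named here.

Compound 1 `CCCN(CC[C@H]1CC[C@H](NC(=O)/C=C/c2cccc(Cl)c2)CC1)[C@H]1CCc2nc(N)sc2C1`: in an assay on brain for displacement of a labelled ligand from D(3) dopamine receptor (Rattus norvegicus) (on this read-out lower numbers stand for stronger inhibition and higher numbers for weaker inhibition), compound 1 gives 1.2 nM.
Compound 2 `CCCN(CC[C@H]1CC[C@H](NC(=O)/C=C/c2ccccc2OC)CC1)[C@H]1CCc2nc(N)sc2C1`: compound 2 gives 8.1 nM.
Compound 3 `CCCN(CC[C@H]1CC[C@H](NC(=O)c2ccc(-n3ccnc3)cc2)CC1)[C@H]1CCc2nc(N)sc2C1`: compound 3 gives 1.9 nM.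

Among these three numbers compound 3 stands second highest. Its nearest neighbour is compound 1, a 1.6-fold higher number from compound 1 to compound 3 (0.20 log units; within the scatter); its furthest is compound 2, a 4.3-fold lower number from compound 2 to compound 3 (0.63 log units; beyond the scatter). Compound 4 `CCCN(CC[C@H]1CC[C@H](NC(=O)c2ccc(-n3cncn3)cc2)CC1)[C@H]1CCc2nc(N)sc2C1` differs from compound 3 by 1H-1,2,4-triazol-1-yl in place of 1H-imidazol-1-yl on an aromatic carbon. Among the compounds with values here, none of the measured steps touches this five-membered ring alone: a 6.8-fold higher number from compound 1 to compound 2 (0.83 log units; beyond the scatter) and a 4.3-fold lower number from compound 2 to compound 3 (0.63 log units; beyond the scatter) each replace the whole amide tail, a far larger change, and even those moved the number only modestly. Exchanging one ring atom for a nitrogen is a smaller change, so the expected step is a 1.3-fold higher number from compound 3 to compound 4 (0.12 log units; within the scatter), within the scatter, perhaps a slight weakening. Compound 4 is therefore estimated at 2.5 nM, likely between 1 nM and 6.5 nM in this assay.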

Compound 4, inhibition constant: 2.4 nM
For compound 4 the middle estimate is 1.0-fold (0.02 log units) above the measured one; the range from low to high includes it.
By their numbers in this assay, from the lowest: compounds 1, 3 and 4 (each within the scatter of the next); then compound 2.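

In this assay, within the data shown here, the exchange gives a 1.3-fold higher number from compound 3 to compound 4 (0.10 log units; within the scatter) as the first reading of this ring on its own, so the 1H-1,2,4-triazol-1-yl group, with its extra ring nitrogen, serves here as well as 1H-imidazol-1-yl. Against the two other tails, a 2.0-fold higher number from compound 1 to compound 4 (0.30 log units; within the scatter) stays inside the usual variation and a 3.4-fold lower number from compound 2 to compound 4 (0.53 log units; beyond the scatter) goes past it, the same picture compound 3 gave. Nothing measured here explains why the two rings read alike.

Still open, from the compounds shown here alone, is how a simple amine or a carboxylic acid would read on that aromatic carbon in place of the five-membered ring.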